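Changing the sulfonamide ring system of a urea-based activator

A few compounds are considered here, and "the series" means these few. Any claim that something is new, unique, unknown or untested is made for them only; others in the source may bear on it.

Three compounds have numbers in an assay on isolated protein for activation of Nicotinamide phosphoribosyltransferase (Homo sapiens); a lower number here means that less compound is needed, a higher number that more compound is needed for the effect. Compound 1 `O=C(NCc1ccncc1)Nc1ccc(S(=O)(=O)N2CC3CCC(C2)O3)cc1` gives 279 nM in this assay, the lowest of the three. Compound 2 `CCOC(=O)c1ccc(NC(=S)NCc2ccncc2)cc1` gives 9770 nM in this assay, and compound 3 `CCOC(=O)c1ccc(NC(=O)NCc2cnco2)cc1` gives 6900 nM. Compound 1 is separated from both by gaps that lie beyond the scatter, but each of these pairs differs in more than one place, so the numbers alone do not tell which part of the structure carries the gap.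

Compound 4 `O=C(NCc1ccncc1)Nc1ccc(S(=O)(=O)N2CCc3ccccc3C2)cc1` has not been measured. It differs from compound 1 in one place: a group of 10 heavy atoms (9 carbon, 1 nitrogen; one six-membered non-aromatic ring with 1 hetero atom, one six-membered aromatic ring of carbon only) in place of a group of 8 heavy atoms (6 carbon, 1 nitrogen, 1 oxygen; one five-membered non-aromatic ring with 1 hetero atom, one six-membered non-aromatic ring with 2 hetero atoms), on a sulfonyl sulfur. The urea and the pyridylmethyl part of compound 1 are kept unchanged.

Within the data shown here, nothing among the measured compounds isolates an exchange of this kind on the sulfonyl sulfur, so the size of the step is not known from the data. Since the part of compound 1 that sets it apart from compounds 2 and 3 remains in place, compound 4 is expected to stay close to compound 1, with an expected step from compound 1 to compound 4 of a 1.3-fold lower number from compound 1 to compound 4 (0.10 log units; within the scatter), which is within the scatter. Compound 4 is therefore estimated at 220 nM in this assay, with a range from 60 nM to 900 nM.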

Compound 4, half-maximal effective concentration: 142 nM
For compound 4 the middle estimate is 1.5-fold (0.19 log units) above the measured one; the range from low to high includes it.
By their numbers in this assay, from the lowest: compounds 4 and 1 (each within the scatter of the next); then compounds 3 and 2 (each within the scatter of the next).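

Among these compounds, on the sulfonyl sulfur, the exchange of the ring system of compound 1 for 1,2,3,4-tetrahydroisoquinolin-2-yl gives a 2.0-fold lower number from compound 1 to compound 4 (0.29 log units; within the scatter) in this assay, the first single-place comparison in this set. This position therefore takes a group with a six-membered aromatic ring of carbon only and no hydrogen-bond acceptor in place of one with a ring oxygen and one acceptor, and the number stays within the scatter, so for this pair neither that oxygen nor the larger heavy-atom count of the entering group separates the two compounds. No measurement at hand speaks to why the two groups give such similar numbers.

What the compounds shown leave open is how far this tolerance extends, for instance to a simple piperidine, a morpholine or an open-chain diethylamino group on the same sulfonyl sulfur, or to a carboxylic acid carried on the aromatic ring of the tetrahydroisoquinoline. They also leave open which part of the structure carries the gaps to compounds 2 and 3, since those compounds still differ from compound 1 and compound 4 in more than one place.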